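From pyridin-2-yl to ethyl: a modest step expected

The source may report more compounds than this note shows. Statements on the series, on what has been measured and on what is new or still open speak of the compounds shown alone.

For the measured compounds named here, in a functional assay (muscle tissue) with Felis catus as the target (a lower number here means that less compound is needed, a higher number that more compound is needed for the effect), compound 1 `Cc1nc(O)c(C#N)c(NCc2ccccn2)n1` gives 43000 nM as its half-maximal effective concentration, the higher of the two numbers measured so far. On the same shared core, compound 2 `Cc1nc(O)c(C#N)c(NCc2ccco2)n1` gives 10000 nM in this assay and so stands lower.

The unmeasured compound 3 `CCCNc1nc(C)nc(O)c1C#N` also keeps that core and changes one group of compound 1: ethyl in place of pyridin-2-yl on a saturated chain carbon bound to a nitrogen on an aromatic ring.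

Going by the values given here, only one measured step bears on this change, and it is modest but beyond the scatter: a 4.3-fold lower number from compound 1 to compound 2 (0.63 log units; beyond the scatter) with furan-2-yl in place of pyridin-2-yl. Among the compounds with values here, no compound with ethyl at this place has been measured, so this guide is a loose one. A modest step towards a lower number is therefore expected in this assay, resting on compound 2 alone.

For compound 3 the estimated value is 20000 nM with 6000 nM to 60000 nM as the expected range. The expected change is a 2.2-fold lower number from compound 1 to compound 3 (0.33 log units; beyond the scatter) in this estimate.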

Compound 3, half-maximal effective concentration: 1900 nM
For compound 3 the middle estimate is 11-fold (1.02 log units) above the measured one; the whole stated range lies above it.
By their numbers in this assay, from the lowest: compound 3; then compound 2; then compound 1.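

In this assay the change to ethyl gives a 23-fold lower number from compound 1 to compound 3 (1.35 log units; beyond the scatter) as a large step and a 5.3-fold lower number from compound 2 to compound 3 (0.72 log units; beyond the scatter) as a modest one, so at this place, on a saturated chain carbon bound to a nitrogen on an aromatic ring, an aromatic ring is not required for the lowest number seen so far. For the compounds shown here, the earlier pair compared only two aromatic rings, whereas this result shows that ethyl, which has no ring, gives a lower number than both of them, and neither ring-bearing compound goes against this order. Nothing available explains why the number falls when either ring gives way to ethyl.

As far as these compounds go, it remains open whether the number would keep falling, level off or rise with methyl, a longer chain such as butyl, a branched chain such as isopropyl, or a saturated ring such as cyclohexyl in place of ethyl. From the compounds shown here alone, all three compounds also share one core, so it is unknown whether ethyl would give a similar step if another part of the core were changed.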